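This account rests on a few compounds, and the source may have more. Where it says the series, first, only, none or still open, it means among the compounds named here.

Three compounds have been measured in a functional assay on HT-29 cells (Homo sapiens) for cytotoxicity, read by MTT assay, with a stated time of 24 h, tested at 0.64 ug/mL; a higher number here means a stronger effect of the compound at the concentration tested, a lower number a weaker effect:

compound 1 `Cn1c(-c2ccc(NC(=O)CSc3nc4cc(Cl)ccc4o3)cc2)nc(-c2ccccc2)c1-c1ccccc1`: 11.9%
compound 2 `Cn1nnnc1SCC(=O)Nc1ccc(-c2nc(-c3ccccc3)c(-c3ccccc3)n2C)cc1`: 38%
compound 3 `CN(C)/C=C/N1CCN(CC(=O)Nc2ccc(-c3nc(-c4ccccc4)c(-c4ccccc4)n3C)cc2)CC1`: 3.1%

Compound 3 stands lowest of the three numbers. Its nearest neighbour is compound 1, since a number 8.8 percentage points lower from compound 1 to compound 3 (within the scatter) lies within the scatter; its furthest is compound 2, since a number 34.9 percentage points lower from compound 2 to compound 3 (beyond the scatter) lies beyond the scatter. All three share the same core and differ only in the group attached to the carbonyl carbon of the amide.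

Compound 4 `Cn1c(-c2ccc(NC(=O)CN3CCN(c4ccccc4)CC3)cc2)nc(-c2ccccc2)c1-c1ccccc1` keeps the piperazine ring of compound 3 and changes only what sits on its second nitrogen: phenyl in place of 2-(dimethylamino)ethenyl on an amine nitrogen in a ring.

For the measured compounds named here, no measured step isolates this kind of change. The steps that reach compound 3, a number 8.8 percentage points lower from compound 1 to compound 3 (within the scatter) and a number 34.9 percentage points lower from compound 2 to compound 3 (beyond the scatter), each swap the whole sulfur-bearing group for the piperazine group, while a number 26.1 percentage points higher from compound 1 to compound 2 (beyond the scatter) exchanges one group on sulfur for another. Two of these three steps are of modest or large size, so swapping a terminal group can matter, but the pair that shares the piperazine ring gives no guidance on direction. Compound 4 is therefore expected to sit close to compound 3, with a number 5.9 percentage points higher from compound 3 to compound 4 (within the scatter) not beyond the scatter, and its expected value is 9%, within a range from 0% to 28%.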

Compound 4, a percentage reported as activity, at one concentration (the size of the read-out at that concentration, not a potency): 17.3%
For compound 4 the middle estimate is 8.3 percentage points below the measured one, within the range that was stated.
By their numbers in this assay, from the lowest: compounds 3, 1 and 4 (each within the scatter of the next, the first and the last beyond it); then compound 2.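

In this assay, for the compounds shown here, the outer group on the piperazine ring turns out to matter: with the ring and the rest of the molecule kept, phenyl in place of 2-(dimethylamino)ethenyl on an amine nitrogen in a ring gives a number 14.2 percentage points higher from compound 3 to compound 4 (beyond the scatter), and this is the first step that changes only that outer group. The 4-phenylpiperazin-1-yl group still does not match the (1-methyl-1H-tetrazol-5-yl)sulfanyl group, with a number 20.7 percentage points lower from compound 2 to compound 4 (beyond the scatter), while against the (5-chloro-1,3-benzoxazol-2-yl)sulfanyl group it gives a number 5.4 percentage points higher from compound 1 to compound 4 (within the scatter), so these two compounds cannot be told apart in this assay. Nothing measured here accounts for the effect of swapping the outer group on the piperazine ring.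

Only two groups are shown on this nitrogen, so it remains open how a benzyl group, a methyl group or a phenyl ring carrying a chlorine atom would behave there. From the compounds shown here alone, each number is also a read-out at a single concentration and not a potency, so how compound 4 would compare across a range of concentrations remains open too.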